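Benzyl selenoether analogue of a thiophene bis-amide series

The source may hold more compounds than are shown below. What is called first, only, known or untested is meant among the compounds shown, and "the series" means these compounds.

Measured compounds:
Compound 1 `C[Se]/C(=N\C(=O)c1cc2ccccc2s1)NC(=O)c1cc2ccccc2s1`: in a functional assay on HT-29 cells (Homo sapiens) for cytotoxicity, read by MTT assay, with a stated time of 72 h (a higher number here means a weaker inhibitor of growth, a lower number a stronger inhibitor of growth), compound 1 gives > 100000 nM, a limit of the assay.
Compound 2 `CS/C(=N\C(=O)c1csc([N+](=O)[O-])c1)NC(=O)c1csc([N+](=O)[O-])c1`: compound 2 gives > 100000 nM, again a limit.
Compound 3 `C[Se]/C(=N\C(=O)c1cccs1)NC(=O)c1cccs1`: compound 3 gives > 100000 nM, also a limit.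

Compound 3 thus stands at the assay limit, as do the other two values shown, so no number separates them and no order among them can be read. Going by the values given here, no pair of measured compounds differs in one place, so no step size is known from measurement. Compound 4 `O=C(/N=C(/NC(=O)c1cccs1)[Se]Cc1ccccc1)c1cccs1` differs from compound 3 by phenyl in place of hydrogen on a saturated chain carbon bound to a selenium atom. Given that all three values sit at the limit (the limit of > 100000 nM in this assay, at which 3 of the 3 values shown sit), the step expected in this assay is a number no higher from compound 3 to compound 4 (the limit leaves the size open), none beyond the scatter. Compound 4 is therefore expected to give 100000 nM, within a range of 30000 nM to 300000 nM, most probably reported once more only as a limit.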

Compound 4, concentration for total growth inhibition: > 100000 nM
Compound 4: a limit, no number; the forecaster's own chance of this, stated with the estimate: 80%; the middle value lies on the limit itself.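

Compound 3 and compound 4 both stand at a limit, so no step between them can be read: the limit of > 100000 nM in this assay, at which 4 of the 4 values shown sit.

The compounds shown leave open whether any change to the shared core gives a value off this limit.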